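A Hydroxy-to-Chloro Swap at the Detection Limit

This account rests on a few compounds, and the source may have more. Where it says the series, first, only, none or still open, it means among the compounds named here.

Three measured compounds share one core and differ only in the group on the aromatic nitrogen. Compound 1 `C/C=C/n1cc(/C=C/C(=O)CC(=O)C(=O)OCC)c2ccccc21` carries a prop-1-en-1-yl group, compound 2 `C=C(C)Cn1cc(/C=C/C(=O)CC(=O)C(=O)OCC)c2ccccc21` a 2-methylprop-2-en-1-yl group, and compound 3 `CCOC(=O)C(=O)CC(=O)/C=C/c1cn(-c2ccc(O)cc2)c2ccccc12` a 4-hydroxyphenyl group. In an assay on isolated protein for inhibition of DNA nucleotidylexotransferase (Homo sapiens), read by scintillation counting, with a stated time of 10 min (on this read-out lower numbers stand for stronger inhibition and higher numbers for weaker inhibition), compound 1 reaches only the limit of the assay, > 40 uM. Compound 2 likewise stops at the limit, > 40 uM. Compound 3 also gives only the limit, > 40 uM. Because (the limit of > 40 uM in this assay, at which 3 of the 3 values shown sit), compound 3 cannot be placed above or below its two companions, and the steps a step that the two limits leave unreadable from compound 1 to compound 2, a step that the two limits leave unreadable from compound 1 to compound 3 and a step that the two limits leave unreadable from compound 2 to compound 3 stay unreadable in size.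

Compound 4 `CCOC(=O)C(=O)CC(=O)/C=C/c1cn(-c2ccc(Cl)cc2)c2ccccc12` differs from compound 3 in one place: chloro in place of hydroxy on an aromatic carbon. Among the compounds with values here, no measured step reads out a size that bears on this change; every value shown stands at one and the same limit. With no readable step to lean on, the expectation for compound 4 in this assay is again a limit rather than a number, and the step that the limit leaves unreadable from compound 3 to compound 4 is estimated to stay within the usual scatter. Compound 4 is estimated at 60 uM, with a range from 20 uM to 200 uM.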

Compound 4, concentration for 50% inhibition: > 40 uM
Compound 4 was reported as a limit (the forecaster's own chance of this, stated with the estimate: 75%); the middle value is on the limit's open side.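

In this assay compound 4 also gives only a limit, > 40 uM, so its steps from compound 1, compound 2 and compound 3 cannot be read in size: the limit of > 40 uM in this assay, at which 4 of the 4 values shown sit. The compounds shown leave open how strongly any of the four inhibits in this assay, and whether the group on the aromatic nitrogen matters at all.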